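The compounds below may be only part of what the source reports. "The series", "measured", "known", "first", "only" and "open" are said of these compounds alone.

Of the compounds shown here, two of this set have so far been tested in a functional assay on the whole organism (strain Swiss) with Mus musculus as the target, in the maximal electroshock model, with a stated time of 0.25 h, at a dose of 100 mg/kg by the intraperitoneal route; on this read-out lower numbers stand for a weaker effect and higher numbers for a stronger effect at the one dose given. Compound 1, `CCC(C(=O)N1CCN(c2cccc(Cl)c2)CC1)N1C(=O)CCC1=O`, gives 50% there. Compound 2, `COc1cccc(N2CCN(C(=O)C(C)N3C(=O)CCC3=O)CC2)c1`, gives 25% in this assay, the lowest of the two numbers; the nearest one belongs to compound 1, which stands higher by an amount beyond the usual scatter. Compound 1 and compound 2 differ in more than one place, so the gap between them cannot be tied to any single change.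

Compound 3, `CC(C(=O)N1CCN(c2cccc(Cl)c2)CC1)N1C(=O)CCC1=O`, has not yet been measured. It differs from compound 2 in one place only: chloro in place of methoxy on an aromatic carbon. Read one bond further out, the same change turns a 3-methoxyphenyl into a 3-chlorophenyl, the very group that compound 1 carries.

For the measured compounds named here, no pair of measured compounds shows this change on its own, so its size here is uncertain. In this assay an upward step of a number 20 percentage points higher from compound 2 to compound 3 (beyond the scatter) is expected, because compound 1 with the same 3-chlorophenyl gives 50%. Compound 3 is therefore estimated at 45%, within a range from 25% to 65%.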

Compound 3, a percentage reported as activity, at one dose (the size of the read-out at that dose, not a potency): 50%
The estimate for compound 3 lay 5 percentage points below the measured number; low and high end bracket the measured number.
By their numbers in this assay, from the lowest: compound 2; then compounds 1 and 3 (each within the scatter of the next).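

In this assay, chloro in place of methoxy on the aromatic carbon gives a number 25 percentage points higher from compound 2 to compound 3 (beyond the scatter), so this single change, meta to a large group, is now seen on its own and clearly alters the read-out at the one dose given. Hydrogen in place of methyl on the saturated chain carbon gives no change at the digits printed from compound 1 to compound 3 (within the scatter), so with the 3-chlorophenyl in place, this change in the chain leaves the read-out within the usual scatter. Nothing in the data shown explains why the chloro compound stands higher than the methoxy compound.

As far as these compounds go, only methoxy and chloro appear at this aromatic carbon, so it remains open how a group such as fluoro, trifluoromethyl or an amine would read there. From the compounds shown here alone, the chain change is seen only alongside the 3-chlorophenyl, so it also remains open whether it would leave the read-out as little changed alongside a 3-methoxyphenyl, and how a longer chain, such as propyl, would read on that same carbon.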